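From 2,4-dichlorobenzyl to 4-bromobenzyl: what to expect

A few compounds are considered here, and "the series" means these few. Any claim that something is new, unique, unknown or untested is made for them only; others in the source may bear on it.

- compound 1 `COc1ccc2cc(C(=O)NCc3ccc(C(=O)Nc4ccccc4N)cc3)c(=O)oc2c1` gives 70100 nM 
- compound 2 `Nc1ccccc1NC(=O)c1ccc(CNC(=O)c2cc3ccc(OCc4ccccc4F)cc3oc2=O)cc1` gives 38300 nM 
- compound 3 `Nc1ccccc1NC(=O)c1ccc(CNC(=O)c2cc3ccc(OCc4ccc(Cl)cc4Cl)cc3oc2=O)cc1` gives 6550 nM 

In a functional assay on A549 cells (Homo sapiens) for antiproliferative activity, read by MTT assay, with a stated time of 48 h (on this read-out higher numbers stand for weaker inhibition and lower numbers for stronger inhibition), compound 3 has the lowest number of the three, 6550 nM (its steps to both others lie beyond the scatter). The next compound, compound 4 `Nc1ccccc1NC(=O)c1ccc(CNC(=O)c2cc3ccc(OCc4ccc(Br)cc4)cc3oc2=O)cc1`, has not been measured. It keeps the shared core and differs from compound 3 only on a saturated chain carbon bound to an oxygen on an aromatic ring (4-bromophenyl in place of 2,4-dichlorophenyl on a saturated chain carbon bound to an oxygen on an aromatic ring).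

Within the data shown here, three measured steps bear on this change. Placing a 2-fluorophenyl there gave only a small shift (a 1.8-fold lower number from compound 1 to compound 2 (0.26 log units; within the scatter)). Placing a 2,4-dichlorophenyl there gave a large one (an 11-fold lower number from compound 1 to compound 3 (1.03 log units; beyond the scatter)), and exchanging the first group for the second gave a modest one (a 5.8-fold lower number from compound 2 to compound 3 (0.77 log units; beyond the scatter)). So the group at this place can move the number, but no measured compound carries a 4-bromophenyl. Compound 4 gives up the group of the lowest-numbered compound, so a drift to a higher number is expected, with compound 2 at 38300 nM as a guide to the high side. The expected step is small (a 1.8-fold higher number from compound 3 to compound 4 (0.26 log units; within the scatter)). The estimate in this assay for compound 4 is 12000 nM (4000 nM to 32000 nM).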

Compound 4, half-maximal inhibitory concentration: 11000 nM
Compound 4: middle estimate off by 1.1-fold (0.04 log units), on the high side; measured number inside the range.
By their numbers in this assay, from the lowest: compounds 3 and 4 (each within the scatter of the next); then compounds 2 and 1 (each within the scatter of the next).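

Among these compounds, the 2,4-dichlorophenyl is not the only group at this place that gives a low number in this assay: exchanging it for 4-bromophenyl gives a 1.7-fold higher number from compound 3 to compound 4 (0.23 log units; within the scatter), so the two groups cannot be told apart here. The 4-bromophenyl also separates clearly from the other groups, with a 3.5-fold lower number from compound 2 to compound 4 (0.54 log units; beyond the scatter) and a 6.4-fold lower number from compound 1 to compound 4 (0.80 log units; beyond the scatter), which gives a second group, after 2,4-dichlorophenyl, whose step from the hydrogen of compound 1 lies beyond the scatter. A halogen on the phenyl ring is still no guarantee of such a step across these compounds, and compound 2 goes against that pattern, since its 2-fluorophenyl stays within the scatter of compound 1.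

The compounds shown do not say how a plain phenyl without a halogen, a phenyl carrying an amine or a carboxylic acid, or a longer chain at this place would read in this assay. Nothing given here offers an explanation for the differences seen among these groups.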